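Swapping an amine chain for a carboxylic acid chain

The compounds below may be only part of what the source reports. "The series", "measured", "known", "first", "only" and "open" are said of these compounds alone.

Measured compounds:
Compound 1, `NCCCCCCOc1ccc2c(=O)c(-c3ccc(O)cc3)coc2c1`: 100 nM
Compound 2, `O=C(O)CCCCCOc1ccc2c(=O)cc(-c3ccc(O)cc3)oc2c1`: 3500 nM
Compound 3, `CCCCC(Oc1ccc2c(=O)c(-c3ccc(O)cc3)coc2c1)C(=O)OCC`: 4500 nM

In an assay (Cricetulus griseus) for inhibition of aldehyde dehydrogenase, mitochondrial (Homo sapiens) (on this read-out lower numbers stand for stronger inhibition and higher numbers for weaker inhibition), compound 1 gives the lowest number of the three, and its distances to compound 2 and compound 3 both lie beyond the scatter, so it is the strongest inhibitor shown. Compound 4, `CC(Oc1ccc2c(=O)c(-c3ccc(O)cc3)coc2c1)C(=O)O`, has not yet been measured. It differs from compound 1 by 1-carboxyethyl in place of 6-aminohexyl on an oxygen on an aromatic ring. Both compound 2 and compound 3 carry an acid or ester chain on the shared core and give markedly higher numbers than compound 1, so a step that weakens inhibition is expected in this assay. Compound 4 is therefore estimated to land near those two, at 3000 nM (range 800 nM to 12000 nM), a weakening step of a 30-fold higher number from compound 1 to compound 4 (1.48 log units; beyond the scatter) expected because compound 2 gives 3500 nM.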

Compound 4, half-maximal inhibitory concentration: 2500 nM
Compound 4: middle estimate off by 1.2-fold (0.08 log units), on the high side, and the stated range covers the measured number.
By their numbers in this assay, from the lowest: compound 1; then compounds 4, 2 and 3 (each within the scatter of the next).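

In this assay, going by these compounds alone, the swap gives a 25-fold higher number from compound 1 to compound 4 (1.40 log units; beyond the scatter), the first comparison in which only one place changes, with the shared core kept the same. This shows that the group on this oxygen on an aromatic ring strongly affects the read-out, and that 1-carboxyethyl is far less favourable there than 6-aminohexyl. No available data explain this difference. The swap changes chain length and end group together, so their contributions cannot be told apart. A shorter amine chain or a longer carboxylic acid chain on this same core would separate them.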